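Acyl variation on the shared core: compound 2 to compound 3

The source may report more compounds than this note shows. Statements on the series, on what has been measured and on what is new or still open speak of the compounds shown alone.

Compound 1 `CCC(=O)N1N=C(c2cc3ccccc3oc2=O)CC1c1ccccc1` gives 4370 nM in a functional assay on PC-3 cells (Homo sapiens) for cytotoxicity, read by MTT assay, with a stated time of 48 h; a lower number here means a stronger inhibitor, a higher number a weaker inhibitor. Among the measured compounds shown here, compound 2 `O=C(CCl)N1N=C(c2cc3ccccc3oc2=O)CC1c1ccccc1` gives 2980 nM in this assay; the only measured step, a 1.5-fold lower number from compound 1 to compound 2 (0.17 log units; within the scatter), leaves compound 2 level with compound 1 within the scatter. Compound 3 `O=C(c1ccccc1Cl)N1N=C(c2cc3ccccc3oc2=O)CC1c1ccccc1` differs from compound 2 by 2-chlorophenyl in place of chloromethyl on a carbonyl carbon. For the measured compounds named here, no measured step exchanges a chain for an aromatic ring on the carbonyl carbon; the one step known there, a 1.5-fold lower number from compound 1 to compound 2 (0.17 log units; within the scatter), is within scatter, so its bearing is weak. For compound 3 a step of a 1.0-fold higher number from compound 2 to compound 3 (0.00 log units; within the scatter) is expected, nothing beyond the scatter. Compound 3 is estimated at 3000 nM, with a range from 1000 nM to 9000 nM.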

Compound 3, half-maximal inhibitory concentration: 6370 nM
Estimate against measurement, compound 3: 2.1-fold (0.33 log units) below; low and high end bracket the measured number.
By their numbers in this assay, from the lowest: compounds 2, 1 and 3 (each within the scatter of the next, the first and the last beyond it).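

Among the compounds shown here, exchanging a chain for an aromatic ring on the carbonyl carbon gives a 2.1-fold higher number from compound 2 to compound 3 (0.33 log units; beyond the scatter) in this assay, the only step so far to pass the scatter, and it runs towards a weaker compound. Against the ethyl of compound 1, the same ring gives a 1.5-fold higher number from compound 1 to compound 3 (0.16 log units; within the scatter), so the ring separates only from chloromethyl, and the position accepts 2-chlorophenyl with no gain. No available evidence accounts for this step.

Still open, on these data alone, is whether the ring or its chlorine carries the step, which plain phenyl would separate. As far as these compounds go, how an amine or a longer chain on the carbonyl carbon would read also remains open.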